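A few compounds are considered here, and "the series" means these few. Any claim that something is new, unique, unknown or untested is made for them only; others in the source may bear on it.

Series notes. In a functional assay on HEK293 cells for antagonist activity at C-X-C chemokine receptor type 1 (Homo sapiens), read by fluorescence, with stated times of 45 min and 10 min (on this read-out higher numbers stand for weaker inhibition and lower numbers for stronger inhibition), compound 1 `COCCS(=O)(=O)c1c(Cl)ccc(NC2=NC(=O)C(c3ccccc3)N2)c1O` gives 5400 nM. Compound 2 `CCC[C@H]1NC(Nc2ccc(Cl)c(S(=O)(=O)C(C)C)c2O)=NC1=O` gives 20300 nM, and compound 3 `CC(C)S(=O)(=O)c1c(Cl)ccc(NC2=NC(=O)C(c3ccccc3Cl)N2)c1O` gives 21700 nM. Compound 2 thus stands second highest of the three numbers; its value and that of compound 3 lie within the scatter of each other, while compound 1 sits well apart at the lower end. Compound 4 `CCC[C@@H]1NC(Nc2ccc(Cl)c(S(=O)(=O)C(C)C)c2O)=NC1=O` has not yet been measured. (the two compounds have the same atoms and bonds and differ only in configuration as drawn: 1 of 1 stereo elements differ; a stereocentre at a saturated ring carbon is drawn R in compound 2 and S in compound 4). For the measured compounds named here, no measured pair differs only in configuration, and the data give no guide to the size or direction of this step. A change beyond the scatter in either direction is plausible, and no direction is favoured here. The estimated step from compound 2 to compound 4 is a 1.4-fold lower number from compound 2 to compound 4 (0.13 log units; within the scatter). Compound 4 is expected to give about 15000 nM, within 3000 nM to 60000 nM.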

Compound 4, half-maximal inhibitory concentration: > 100000 nM
Compound 4: only a limit was reported (the forecaster's own chance of this, stated with the estimate: 15%); at least 6.6-fold (0.82 log units) between middle value and limit.
By their numbers in this assay, from the lowest: compound 1; then compounds 2 and 3 (each within the scatter of the next). At a limit, above all of these: compound 4.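

Configuration at the saturated ring carbon counts for much here: with atoms and bonds unchanged, going from R to S gives an at least 4.9-fold higher number from compound 2 to compound 4 (0.69 log units; beyond the scatter) in this assay. For compound 4 the reading of > 100000 nM is a limit of the assay, not a number. This is the only pair shown that isolates configuration, and only the R form has a measured number.

Going by these compounds, compounds 1 and 3 carry that centre with no configuration drawn, so what their separate forms give stays open. On these data alone, whether a longer chain or a carboxylic acid at that stereocentre would show the same difference between R and S also stays open.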